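A few compounds are considered here, and "the series" means these few. Any claim that something is new, unique, unknown or untested is made for them only; others in the source may bear on it.

The shared core is shown by compound 1 `CC(C)[C@@H]1CC[C@@H](C)C[C@@]12N(C)C(=O)[C@@H]1[C@H]3C(=O)NC(=O)[C@H]3ON12`. In a functional assay, with a stated time of 20 min, tested at 1 mg/mL (on this read-out higher numbers stand for a stronger effect at the one concentration tested and lower numbers for a weaker effect), compound 1 gives 39.3%. Compound 2 `CC(C)[C@@H]1CC[C@@H](C)C[C@@]12N(C)C(=O)[C@@H]1[C@H]3C(=O)N(C)C(=O)[C@H]3ON12` carries a methyl in place of hydrogen on an amide-type nitrogen in a ring, and in this assay compound 2 gives 43.1%. For the measured compounds named here, the single measured step, a number 3.8 percentage points higher from compound 1 to compound 2 (within the scatter), lies within the scatter, so the two numbers cannot be ordered. Compound 2 stands at the higher of the two numbers, with compound 1 nearest, the gap within the scatter.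

Compound 3 `Cc1cccc(N2C(=O)[C@H]3[C@H](ON4[C@@H]3C(=O)N(C)[C@@]43C[C@H](C)CC[C@H]3C(C)C)C2=O)c1` differs from compound 2 by 3-methylphenyl in place of methyl on an amide-type nitrogen in a ring. The only measured step concerns a far smaller change at the same nitrogen and was within the scatter; no step involving an aromatic ring at this place has been measured, so nothing shown bears directly on the size or direction of the change. Compound 3 is therefore expected to give 40% in this assay, with a range from 15% to 65%. The step from compound 2 is expected to be a number 3.1 percentage points lower from compound 2 to compound 3 (within the scatter), with no direction favoured.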

Compound 3, a percentage reported as activity, at one concentration (the size of the read-out at that concentration, not a potency): 38.7%
Compound 3: the middle estimate sits 1.3 percentage points above what was measured; low and high end bracket the measured number.
By their numbers in this assay, from the lowest: compounds 3, 1 and 2 (each within the scatter of the next).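

On the nitrogen of the five-membered ring, in this assay, the step reads a number 4.4 percentage points lower from compound 2 to compound 3 (within the scatter) for 3-methylphenyl in place of methyl and a number 0.6 percentage points lower from compound 1 to compound 3 (within the scatter) for 3-methylphenyl in place of hydrogen. The earlier pair covered only hydrogen and methyl; compound 3 extends the comparison to a group with a six-membered aromatic ring, and hydrogen, methyl and 3-methylphenyl at this amide-type nitrogen still cannot be told apart on this read-out, so compound 1, compound 2 and compound 3 have no order among them. Nothing among the information available explains this result or bears on it.

From the compounds shown here alone, whether any group at this nitrogen can move the number beyond the scatter remains open, for instance a longer chain, a benzyl group, or a phenyl ring carrying a carboxylic acid or an amine. Also open, going by these compounds, is what a change elsewhere on the shared core would do, since all three compounds differ at this nitrogen alone, and how they would compare at other concentrations, since a single-concentration read-out is not a potency.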